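Piperazine variation on the shared core: metabolic stability notes

A few compounds are considered here, and "the series" means these few. Any claim that something is new, unique, unknown or untested is made for them only; others in the source may bear on it.

Compound 1 `CN(C[C@H]1Cc2c(cccc2N2CCN(C3COC3)CC2)CN1)[C@H]1CCCc2cccnc21`: 50.8%
Compound 2 `CN(C[C@H]1Cc2c(cccc2N2CCN(c3cccc(C(F)(F)F)c3)CC2)CN1)[C@H]1CCCc2cccnc21`: 72.3%
Compound 3 `FC1(F)CCC(CN(C[C@H]2Cc3c(cccc3N3CCNCC3)CN2)[C@H]2CCCc3cccnc32)CC1`: 76.6%

In an ADME assay on microsomes from liver (Mus musculus) for metabolic stability, read by LC-MS, with a stated time of 10 min (on this read-out higher numbers stand for a more stable compound and lower numbers for a less stable compound), compound 1 stands lowest of the three numbers; compound 2 and compound 3 each lie beyond the scatter above it. Among the compounds with values here, the one measured step at this position is a number 21.5 percentage points higher from compound 1 to compound 2 (beyond the scatter), a change on the amine nitrogen in the ring only. Compound 4 `CN(C[C@H]1Cc2c(cccc2N2CCNC(C)(C)C2)CN1)[C@H]1CCCc2cccnc21` differs from compound 1 by 3,3-dimethylpiperazin-1-yl in place of 4-(oxetan-3-yl)piperazin-1-yl on an aromatic carbon. Within the data shown here, no measured step alters the piperazine ring itself, so that step bears only loosely; it suggests that changing this part moves the read-out upward rather than downward. Compound 4 is therefore expected to give 58% in this assay, between 44% and 72%. This amounts to an expected step of a number 7.2 percentage points higher from compound 1 to compound 4 (within the scatter), possibly within the scatter.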

Compound 4, percent of the compound remaining: 44%
The estimate for compound 4 lay 14 percentage points above the measured number; measured number inside the range.
By their numbers in this assay, from the lowest: compounds 4 and 1 (each within the scatter of the next); then compounds 2 and 3 (each within the scatter of the next).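

In this assay, the exchange of 4-(oxetan-3-yl)piperazin-1-yl for 3,3-dimethylpiperazin-1-yl gives a number 6.8 percentage points lower from compound 1 to compound 4 (within the scatter). At this position, then, removing the oxetane does not by itself separate the two compounds, and the step beyond the scatter seen with the 3-(trifluoromethyl)phenyl group does not extend to this change. No available measurement explains the result.

As far as these compounds go, both the oxetane and the two methyl groups change in this single step, so their separate contributions remain open. A plain piperazine or a morpholine on the core of compound 1 would help separate them.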